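The source may report more compounds than this note shows. Statements on the series, on what has been measured and on what is new or still open speak of the compounds shown alone.

Compound 1 `COc1ccc(/C=C/c2cc(OC)c(OC)c(OC)c2-c2ccccc2)cc1`: 11000 nM in a functional assay on SK-N-SH cells (Homo sapiens) for cytotoxicity, read by MTT assay, with a stated time of 48 h; a higher number here means a weaker inhibitor, a lower number a stronger inhibitor
Compound 2 `COc1ccc(/C=C/c2cc(OC)c(OC)c(OC)c2-c2ccc(F)c(C)c2)cc1`: 19000 nM

Compound 1 stands at the lower of the two numbers, and compound 2 sits at a gap of a 1.7-fold higher number from compound 1 to compound 2 (0.24 log units; within the scatter) from it, a difference that does not exceed the scatter. Compound 3 `COc1ccc(/C=C/c2cc(OC)c(OC)c(OC)c2-c2ccc(OC)c(OC)c2)cc1` is not yet measured. It differs from compound 1 in this way: 3,4-dimethoxyphenyl in place of phenyl on an aromatic carbon. Among the compounds with values here, only the step from compound 1 to compound 2 is available for comparison, and it moved the number little. Compound 3 is therefore expected to stay near compound 1, with an expected step of a 1.1-fold higher number from compound 1 to compound 3 (0.04 log units; within the scatter), within the scatter. The estimate for compound 3 is 12000 nM, between 3500 nM and 40000 nM.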

Compound 3, half-maximal inhibitory concentration: 42000 nM
The estimate for compound 3 lay 3.5-fold (0.54 log units) below the measured number; the whole stated range lies below it.
By their numbers in this assay, from the lowest: compounds 1 and 2 (each within the scatter of the next); then compound 3.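

In this assay, the group on this aromatic carbon now proves able to move the number: 3,4-dimethoxyphenyl gives a 3.8-fold higher number from compound 1 to compound 3 (0.58 log units; beyond the scatter) and also a 2.2-fold higher number from compound 2 to compound 3 (0.34 log units; beyond the scatter) in the comparison with 4-fluoro-3-methylphenyl. Both steps are modest but lie beyond the scatter, whereas the step from phenyl to 4-fluoro-3-methylphenyl did not. Nothing available accounts for this rise. On these data alone, whether one methoxy group alone would produce the step remains open. So does how a hydroxyl group or an amine on this ring would read.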